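A few compounds are considered here, and "the series" means these few. Any claim that something is new, unique, unknown or untested is made for them only; others in the source may bear on it.

Compound 1 (`COc1ccc(-c2cccc(=O)n2-c2cc(OC)c(OC)c(OC)c2)cc1O`) gives < 10 nM in a functional assay on HepG2 cells (Homo sapiens) for cytotoxicity, read by spectrophotometry, with a stated time of 72 h (a higher number here means a weaker inhibitor, a lower number a stronger inhibitor), as its reading, and this is a limit of the assay and not a number. Compound 2 (`COc1ccc(-c2cccc(=O)n2-c2cc(OC)c(OC)c(OC)c2)cc1C`) gives 129 nM in this assay as a measured number. Compound 3 (`COc1ccc(-n2c(-c3cc(OC)c(OC)c(OC)c3)cccc2=O)cc1OCc1ccccc1`) stands highest of the numbers shown at 3040 nM in this assay and lies beyond the scatter from compound 2. Its groups are arranged differently on the core, so it is not a single-place neighbour of the other two.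

Compound 4 (`COc1ccc(-n2c(-c3cc(OC)c(OC)c(OC)c3)cccc2=O)cc1`) has hydrogen in place of benzyloxy on an aromatic carbon, ortho to a methoxy group and meta to a large group (hydrogen in place of benzyloxy on an aromatic carbon). Among the measured compounds shown here, only one measured step changes a single place, and it is an at least 12-fold higher number from compound 1 to compound 2 (1.11 log units; beyond the scatter) with methyl in place of hydroxy on an aromatic carbon. That large step shows that one small substituent can move the number strongly in this family, but it involves different groups in the other arrangement, so it supports only a loose expectation.

A moderate fall is expected, with a 4.3-fold lower number from compound 3 to compound 4 (0.64 log units; beyond the scatter) as the estimated step in this assay and with no change beyond the scatter also possible. For compound 4 the estimated value is 700 nM in this assay with an expected range from 80 nM to 5000 nM before the measurement is known.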

Compound 4, half-maximal inhibitory concentration: 5740 nM
For compound 4 the middle estimate is 8.2-fold (0.91 log units) below the measured one; the measured number lies above the stated range.
By their numbers in this assay, from the lowest: compound 2; then compounds 3 and 4 (each within the scatter of the next). At a limit, below all of these: compound 1.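

In the arrangement shared by compound 3 and compound 4, hydrogen in place of benzyloxy on an aromatic carbon, ortho to a methoxy group and meta to a large group, gives a 1.9-fold higher number from compound 3 to compound 4 (0.28 log units; within the scatter) in this assay. At this position, then, the loss of a group of 8 heavy atoms with its six-membered aromatic ring does not separate the two compounds, whereas the earlier change of hydroxy to methyl, in the other arrangement, gave a large step from a much smaller exchange. No measurement shown here explains why this change leaves the reading within the scatter.

What the compounds shown leave open is whether this position is insensitive to every substituent in this arrangement, or whether a hydroxy group, an amine or a carboxylic acid placed there would move the number beyond the scatter. They also leave open whether benzyloxy and hydrogen would read alike in the other arrangement, that of compound 1, where a single small substituent matters so strongly.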